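Moving the chlorine on a pyridine-based topoisomerase inhibitor series

A few compounds are considered here, and "the series" means these few. Any claim that something is new, unique, unknown or untested is made for them only; others in the source may bear on it.

Measured compounds:
compound 1 `Oc1ccc(-c2cc(-c3cccs3)nc(-c3ccccc3Cl)c2)cc1` — 2.2%
compound 2 `Oc1cccc(-c2cc(-c3ccc(Cl)cc3)nc(-c3cccs3)c2)c1` — 15.1%
compound 3 `Oc1cccc(-c2cc(-c3ccc(Cl)cc3)nc(-c3ccsc3)c2)c1` — 11.7%

Of the compounds shown here, three have been measured in an assay on isolated protein for inhibition of DNA topoisomerase 1 (Homo sapiens), with a stated time of 30 min, tested at 100 uM; a higher number here means a stronger effect of the compound at the concentration tested, a lower number a weaker effect. Compound 2 gives 15.1%, the highest of the three numbers. Compound 3 gives 11.7%, and the step of a number 3.4 percentage points lower from compound 2 to compound 3 (within the scatter) lies within the scatter, so these two cannot be ordered. Compound 1, which also carries a 2-chlorophenyl group, gives 2.2%, a number well beyond the scatter below compound 2.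

The step considered here leads from compound 2 to compound 4 `Oc1cccc(-c2cc(-c3cccs3)nc(-c3ccccc3Cl)c2)c1`. The two have the same atoms, joined differently: 2-chlorophenyl in place of 4-chlorophenyl on an aromatic carbon.

For the measured compounds named here, no measured step bears directly on this change. Going by the values given here, the only step on record, from compound 2 to compound 3, concerns a different group and lies within the scatter. Among the compounds with values here, the one measured compound that carries a 2-chlorophenyl group, compound 1, shows a low number, but it differs from compound 4 in more than one place, so it gives only a loose hint. Compound 4 is therefore expected to land somewhat below compound 2, with an expected step of a number 7.1 percentage points lower from compound 2 to compound 4 (within the scatter). In this assay compound 4 is estimated at 8%, within a range from 0% to 20%.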

Compound 4, a percentage reported as inhibition, at one concentration (the size of the read-out at that concentration, not a potency): 2.7%
Compound 4: the middle estimate sits 5.3 percentage points above what was measured, and the stated range covers the measured number.
By their numbers in this assay, from the lowest: compounds 1, 4, 3 and 2 (each within the scatter of the next, the first and the last beyond it).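

In this assay, for the compounds shown here, shifting the chlorine from 4-chlorophenyl to 2-chlorophenyl on the aromatic carbon next to the ring nitrogen gives a number 12.4 percentage points lower from compound 2 to compound 4 (beyond the scatter), the first step in this small set that lies beyond the scatter and the first clean reading of this change. The other new step, a number 0.5 percentage points higher from compound 1 to compound 4 (within the scatter), shows that with the 2-chlorophenyl group in place, 3-hydroxyphenyl and 4-hydroxyphenyl cannot be told apart, so the low number of compound 1 now has a close match that differs from it in one place only. Nothing available explains why the place of the chlorine matters in this assay.

Going by these compounds, whether a 3-chlorophenyl group at this carbon would fall with compound 2 or with compound 4 remains open, as does whether a methoxy group or an amine in place of the chlorine would hold the number of compound 2. Also open, on these data alone, is whether the same shift of the chlorine would carry over to the thiophen-3-yl group of compound 3, and the single test concentration leaves potency unresolved.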